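Sulfur in place of oxygen on a carbonyl carbon

This account rests on a few compounds, and the source may have more. Where it says the series, first, only, none or still open, it means among the compounds named here.

In an ADME assay on cells (Hepatocyte, Homo sapiens) for metabolic stability, read by LC-MS, with a stated time of 10 min, tested at 1 uM (a lower number here means slower removal, a higher number faster removal of the compound), compound 3 (`O=C(NCc1ccc(S(=O)(=O)c2cccc(C(F)(F)F)c2)cc1)c1cc2ccncc2o1`) gives 10 mL/min/kg. This sits level with compound 1 (`O=C(NCc1ccc(S(=O)(=O)c2cccc(C(F)(F)F)c2)cc1)c1cc2cnccc2[nH]1`), which gives 10 mL/min/kg. Compound 2 (`O=C(NCc1ccc(S(=O)(=O)c2cc(F)cc(F)c2)cc1)c1cnc2nccn2c1`) gives 6 mL/min/kg, within the scatter of both, so the three measured compounds are not separated on these numbers.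

Compound 4 (`O=C(NCc1ccc(S(=O)(=O)c2cccc(C(F)(F)F)c2)cc1)c1cc2ccncc2s1`) departs from compound 3 in one place only: a group of 9 heavy atoms (7 carbon, 1 nitrogen, 1 sulfur; one five-membered aromatic ring with 1 hetero atom, one six-membered aromatic ring with 1 hetero atom) in place of a group of 9 heavy atoms (7 carbon, 1 nitrogen, 1 oxygen; one five-membered aromatic ring with 1 hetero atom, one six-membered aromatic ring with 1 hetero atom), on a carbonyl carbon. The change lies on a carbonyl carbon whose other neighbours are: amide-type nitrogen.

For the measured compounds named here, one measured step bears on it directly: no change at the digits printed from compound 1 to compound 3 (within the scatter). That step is an exchange at the same carbonyl carbon, and it stayed within the scatter. Compound 2 differs from compound 1 and compound 3 in more than one place, so it offers no clean comparison. Going by the values given here, no measured pair shows sulfur taking the place of oxygen, which leaves that single flat step as the only guide, and a thin one.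

On that basis, no step beyond the scatter is expected, and the estimate is no change at the digits printed from compound 3 to compound 4 (within the scatter). The expected value for compound 4 is 10 mL/min/kg, with an estimated range from 5 mL/min/kg to 19 mL/min/kg.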

Compound 4, clearance: 14 mL/min/kg
Beside the measured number, compound 4's estimate is 1.4-fold (0.15 log units) below it; the measured number falls inside the stated range.
By their numbers in this assay, from the lowest: compounds 2, 1, 3 and 4 (each within the scatter of the next, the first and the last beyond it).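

In this assay, the exchange of oxygen for sulfur in the group on the carbonyl carbon gives a 1.4-fold higher number from compound 3 to compound 4 (0.15 log units; within the scatter), and the exchange of the group of compound 1 for the same sulfur-bearing group gives a 1.4-fold higher number from compound 1 to compound 4 (0.15 log units; within the scatter). Read with no change at the digits printed from compound 1 to compound 3 (within the scatter), these steps show that the three groups on this carbonyl carbon, each with one five-membered and one six-membered aromatic ring, are not separated in this measurement, so sulfur joins oxygen and nitrogen among the exchanges that stay within the scatter here. The result widens that flat picture from a single step to all three pairs among these compounds, but nothing available explains the small differences in the printed numbers.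

The compounds shown leave open whether this position stays as flat with a group of a different kind on the carbonyl carbon, such as a plain phenyl ring, a saturated piperidine ring or an open alkyl chain. They also leave open whether the sulfur and oxygen groups would compare in the same way if the trifluoromethyl group were replaced by a nitrile or a methoxy group.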